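The source may report more compounds than this note shows. Statements on the series, on what has been measured and on what is new or still open speak of the compounds shown alone.

Series notes. Three compounds share one core; the read-out throughout is a functional assay on Jurkat cells (Homo sapiens) for inhibition; on this read-out lower numbers stand for stronger inhibition and higher numbers for weaker inhibition. Compound 1 `CC(C)[C@H](NC(=O)COc1cccc2ccccc12)C(=O)N[C@@H](CC(=O)O)C(=O)CSc1nc(-c2ccccc2)c(-c2ccccc2)[nH]1` carries a diphenylimidazolyl sulfanyl group on the chain carbon bound to the carbonyl. In this assay compound 1 returns only a limit, > 200000 nM. Compound 2 `CC(C)[C@H](NC(=O)COc1cccc2ccccc12)C(=O)N[C@@H](CC(=O)O)C(=O)CSC1=NCCS1` carries a thiazoline sulfanyl group at the same place. In this assay compound 2 likewise returns only a limit, > 200000 nM. Compound 3 `CC(C)[C@H](NC(=O)COc1cccc2ccccc12)C(=O)N[C@@H](CC(=O)O)C(=O)CSc1nc2ccccc2[nH]1` carries the benzimidazolyl sulfanyl group. In this assay compound 3 again returns only a limit, > 200000 nM. Compound 3 therefore stands nowhere distinguishable from the other two; all three sit at the limit of > 200000 nM in this assay, at which 3 of the 3 values shown sit. Among the measured compounds shown here, the one step between measured compounds, a step that the two limits leave unreadable from compound 2 to compound 3, is unreadable because the limit of > 200000 nM in this assay, at which 3 of the 3 values shown sit, caps both values.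

Compound 4 `CC(C)[C@H](NC(=O)COc1cccc2ccccc12)C(=O)N[C@@H](CC(=O)O)C(=O)COc1ncnc2ccccc12` is not yet measured. It differs from compound 3 by (quinazolin-4-yl)oxy in place of (1H-benzimidazol-2-yl)sulfanyl on a saturated chain carbon bound to a carbonyl carbon. For the measured compounds named here, no measured step bears on this change, and no measured step is readable, so no size or direction can be drawn from the numbers at hand. For compound 4 the expectation in this assay is 50000 nM, within 1000 nM to 200000 nM, with a substantial chance that only a limit is reported. The step from compound 3 that this estimate implies is an at least 4.0-fold lower number from compound 3 to compound 4 (0.60 log units; beyond the scatter), stated as an expectation only.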

Compound 4, half-maximal inhibitory concentration: > 200000 nM
Compound 4: only a limit was reported; the forecaster's own chance of this, stated with the estimate: 50%; at least 4.0-fold (0.60 log units) between middle value and limit.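

Compound 4, like compound 1, compound 2 and compound 3, returns only a limit in this assay, so the steps from compound 2 and compound 3 to compound 4 cannot be read: the limit of > 200000 nM in this assay, at which 4 of the 4 values shown sit. The compounds shown leave open whether any group at this place gives a measurable inhibition value.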